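Thienopyridine thioureas: amide aryl swap, MKN-74 growth

This account rests on a few compounds, and the source may have more. Where it says the series, first, only, none or still open, it means among the compounds named here.

Measured so far:
compound 1 `NC(=O)c1c(NC(=O)c2ccccc2Cl)sc2c1CCN(C(=S)Nc1cc(C(F)(F)F)cc(C(F)(F)F)c1)C2` — 15000 nM
compound 2 `Cc1ccccc1C(=O)Nc1sc2c(c1C(N)=O)CCN(C(=S)Nc1ccccc1C(F)(F)F)C2` — 17400 nM

Two members of this series have been run in a functional assay on MKN-74 cells (Homo sapiens) for antiproliferative activity, with a stated time of 24 h; on this read-out lower numbers stand for stronger inhibition and higher numbers for weaker inhibition. Compound 1 gives 15000 nM in this assay, and compound 2 gives 17400 nM. Compound 1 holds the lower number of the two, but the gap to compound 2 lies within the scatter, so the two cannot be ranked on these data. Compound 2 differs from compound 1 in more than one place, so its number says nothing on its own about either change.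

Compound 3 `NC(=O)c1c(NC(=O)c2cccc([N+](=O)[O-])c2)sc2c1CCN(C(=S)Nc1cc(C(F)(F)F)cc(C(F)(F)F)c1)C2` is the next member to be measured in this assay. It comes from compound 1 by one change: 3-nitrophenyl in place of 2-chlorophenyl on a carbonyl carbon. For the measured compounds named here, no pair of measured compounds differs in that place alone, so there is no measured step to lean on. Given that the two known numbers sit close together, the step of no change at the digits printed from compound 1 to compound 3 (within the scatter) is expected to stay inside the scatter, with no set direction. Compound 3 is therefore estimated at 15000 nM in this assay, in a range from 5000 nM to 50000 nM.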

Compound 3, half-maximal inhibitory concentration: 25800 nM
Beside the measured number, compound 3's estimate is 1.7-fold (0.24 log units) below it; low and high end bracket the measured number.
By their numbers in this assay, from the lowest: compounds 1, 2 and 3 (each within the scatter of the next).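

In this assay, for the compounds shown here, the step of a 1.7-fold higher number from compound 1 to compound 3 (0.24 log units; within the scatter) is the first reading of the group on the amide carbonyl taken alone, since compound 2 differs from compound 1 in more than one place. Replacing 2-chlorophenyl with 3-nitrophenyl on this carbonyl carbon changes the substituent on the aromatic ring and adds hydrogen-bond acceptors, yet the step stays within the scatter, so these two aryl groups cannot be ranked at this position. No measurement bears on why the number stays within the scatter across this swap.

From the compounds shown here alone, whether any group at this carbonyl carbon can move the number beyond the scatter remains open, for example a phenyl ring carrying an amine or a carboxylic acid, or a longer alkyl chain in place of the aromatic ring. Going by these compounds alone, compound 2 also has no single-place step to either of the other compounds, so the separate contributions of its two differences from compound 1 remain unresolved.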